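Oxadiazole benzyl swap in a sulfonamide EP1 series

The source may hold more compounds than are shown below. What is called first, only, known or untested is meant among the compounds shown, and "the series" means these compounds.

Measured compounds:
compound 1 `CCOc1ccc(Cc2nnc(CN(c3cccc(Cl)c3C)S(=O)(=O)c3ccc(C)cc3)o2)cc1` — 3.98 nM
compound 2 `COc1ccc(Cc2nnc(CN(c3cccc(Cl)c3Cl)S(=O)(=O)c3ccc(C)cc3)o2)cc1` — 7.94 nM

In an assay on CHO cells for displacement of a labelled ligand from prostaglandin E2 receptor EP1 subtype (Homo sapiens) (a lower number here means a stronger inhibitor, a higher number a weaker inhibitor), compound 1 gives 3.98 nM. Compound 2 gives 7.94 nM in this assay. Compound 1 has the lower of the two numbers, but the gap to compound 2 lies within the usual scatter, so the two are not ordered with any confidence.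

Compound 3 `Cc1ccc(S(=O)(=O)N(Cc2nnc(Cc3ccc(Cl)cc3Cl)o2)c2cccc(Cl)c2C)cc1` has not yet been measured in this assay. It differs from compound 1 in one place: 2,4-dichlorophenyl in place of 4-ethoxyphenyl on a saturated chain carbon bound to an aromatic carbon. The group that enters carries no hydrogen-bond acceptor, while the group that leaves carries one. Going by the values given here, no step between two measured compounds covers this change, so the expected step from compound 1 to compound 3, a 2.5-fold higher number from compound 1 to compound 3 (0.40 log units; beyond the scatter), rests on the change alone and is expected to be a small to moderate loss, possibly no larger than the scatter. For compound 3 a value of 10 nM is estimated, between 3 nM and 40 nM.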

Compound 3, half-maximal inhibitory concentration: 63.1 nM
The estimate for compound 3 lay 6.3-fold (0.80 log units) below the measured number; the whole stated range lies below it.
By their numbers in this assay, from the lowest: compounds 1 and 2 (each within the scatter of the next); then compound 3.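

Read in this assay the place on a saturated chain carbon bound to an aromatic carbon proves sensitive to the group it carries: 2,4-dichlorophenyl in place of 4-ethoxyphenyl brings a 16-fold higher number from compound 1 to compound 3 (1.20 log units; beyond the scatter) as a single change. Going by these compounds alone, compound 1 and compound 2 differ in more than one place, so neither of them could isolate this position, and this is the first reading of a change here alone. Nothing at hand accounts for the size of this step.

The step does not separate the departure of the ethoxy group from the arrival of the two chlorines, and a plain phenyl or a 4-chlorophenyl at the same place would bear on that. On these data alone, whether the same change carries the same cost in the setting of compound 2 also stays open.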